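From (ethoxycarbonyl)methyl to furan-2-yl

A few compounds are considered here, and "the series" means these few. Any claim that something is new, unique, unknown or untested is made for them only; others in the source may bear on it.

Measured in a functional assay (aorta) with Rattus norvegicus as the target; on this read-out higher numbers stand for weaker inhibition and lower numbers for stronger inhibition:
- compound 1 `CC1(C)Oc2ccc(C#N)cc2[C@@H](/N=C(\NC#N)Nc2ccc(Cl)cc2)[C@@H]1O`: 1800 nM
- compound 2 `CCOC(=O)CCN(c1ccccc1)[C@H]1c2cc(C#N)ccc2OC(C)(C)[C@@H]1O`: 54000 nM

Of these two, compound 2 has the higher number, beyond the scatter of the assay. Compound 3 `CC1(C)Oc2ccc(C#N)cc2[C@H](N(Cc2ccco2)c2ccccc2)[C@H]1O` is still to be measured. It carries furan-2-yl in place of (ethoxycarbonyl)methyl on a saturated chain carbon bound to a nitrogen on an aromatic ring. Among the compounds with values here, no measured pair shows this change. Within the data shown here, the only guide is that compound 1 reaches 1800 nM, so a moderate move to a lower number is expected, with low confidence. The expected change is a 3.6-fold lower number from compound 2 to compound 3 (0.56 log units; beyond the scatter). For compound 3 the estimate is 15000 nM, with an expected range of 3000 nM to 70000 nM.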

Compound 3, half-maximal inhibitory concentration: 12000 nM
The estimate for compound 3 lay 1.3-fold (0.10 log units) above the measured number; measured number inside the range.
By their numbers in this assay, from the lowest: compound 1; then compound 3; then compound 2.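

In this assay, within the data shown here, furan-2-yl in place of (ethoxycarbonyl)methyl on a saturated chain carbon bound to a nitrogen on an aromatic ring gives a 4.5-fold lower number from compound 2 to compound 3 (0.65 log units; beyond the scatter) and so gives the first reading of this position. The number therefore responds to this group, and an aromatic five-membered ring is accepted there without the ester. Nothing available accounts for the size of this step.

With a single step, the separate roles of the ring and of losing the ester remain unresolved. An amine, a carboxylic acid or a longer chain at this place remains an open comparison.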